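The source may report more compounds than this note shows. Statements on the series, on what has been measured and on what is new or still open speak of the compounds shown alone.

Measured in a toxicity assay on microsomes from liver (Homo sapiens) for metabolic stability, read by LC-MS, using NADPH, tested at 1 uM; on this read-out higher numbers stand for fast clearance and lower numbers for slow clearance:
- compound 1 `Cc1nc(C)n(CC(=O)N2CCN(c3sc(C(F)(F)F)nc3-c3cnc(OC(C)C)nc3)C[C@H]2C)n1`: 16 mL.min-1.g-1
- compound 2 `Cc1nc(C)n(CC(=O)N2CCN(c3sc(C(F)(F)F)nc3-c3cnc(OC4CCC4)nc3)C[C@H]2C)n1`: 51 mL.min-1.g-1

Compound 2 holds the higher of the two values. Compound 3 `CCc1ncc(-c2nc(C(F)(F)F)sc2N2CCN(C(=O)Cn3nc(C)nc3C)[C@H](C)C2)cn1` differs from it by ethyl in place of cyclobutyloxy on an aromatic carbon. Among the measured compounds shown here, only one measured step bears on this, the modest 3.2-fold higher number from compound 1 to compound 2 (0.50 log units; beyond the scatter), and no measured compound carries ethyl. Compound 1 lacks the four-membered ring and gives 16 mL.min-1.g-1, so a modest step down is expected in this assay. The expected change is a 2.6-fold lower number from compound 2 to compound 3 (0.41 log units; beyond the scatter). For compound 3 the estimated value is 20 mL.min-1.g-1, with an expected range of 8 mL.min-1.g-1 to 50 mL.min-1.g-1.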

Compound 3, intrinsic clearance in microsomes: 43 mL.min-1.g-1
The estimate for compound 3 lay 2.2-fold (0.33 log units) below the measured number; the range from low to high includes it.
By their numbers in this assay, from the lowest: compound 1; then compounds 3 and 2 (each within the scatter of the next).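

In this assay, ethyl in place of cyclobutyloxy, on the aromatic carbon between two ring nitrogen atoms, gives a 1.2-fold lower number from compound 2 to compound 3 (0.07 log units; within the scatter), so these two groups cannot be told apart here despite their different size and the loss of the ring and the oxygen. Ethyl in place of isopropoxy gives a 2.7-fold higher number from compound 1 to compound 3 (0.43 log units; beyond the scatter), which leaves compound 1 alone at the low end; the oxygen alone does not mark the low number, as compound 2 also carries it. Nothing measured on these compounds accounts for the pattern. 

Going by these compounds, whether a methoxy group, a longer chain or an amine at this carbon would read like isopropoxy or like ethyl remains open.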